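A Methoxy Group in Place of Tert-Butyl on Compound 3

This account rests on a few compounds, and the source may have more. Where it says the series, first, only, none or still open, it means among the compounds named here.

Compound 3 `CC(C)(C)c1ccc(-c2cc(N3CCC(CNS(N)(=O)=O)CC3)ncn2)cc1` gives 19300 nM in a functional assay on M21 cells (Homo sapiens) for antiproliferative activity, read by sulforhodamine B assay, with a stated time of 48 h (a higher number here means a weaker inhibitor of growth, a lower number a stronger inhibitor of growth), the lowest of the two numbers shown. Compound 2 `CCCCc1ccc(-c2cc(N3CCC(CNS(N)(=O)=O)CC3)ncn2)cc1` gives 47200 nM in this assay. For compound 1 `NS(=O)(=O)NCC1CCN(c2cc(-c3ccccc3)ncn2)CC1` this assay reports only a limit, > 100000 nM, as noted by the limit of > 100000 nM in this assay, at which 1 of the 3 values shown sits. Compound 4 `COc1ccc(-c2cc(N3CCC(CNS(N)(=O)=O)CC3)ncn2)cc1` differs from compound 3 by methoxy in place of tert-butyl on an aromatic carbon. Among the measured compounds shown here, two measured steps bear on this change, both involving the tert-butyl group: an at least 5.1-fold lower number from compound 1 to compound 3 (0.71 log units; beyond the scatter) and a 2.4-fold lower number from compound 2 to compound 3 (0.39 log units; beyond the scatter). Because an at least 5.1-fold lower number from compound 1 to compound 3 (0.71 log units; beyond the scatter) and a 2.4-fold lower number from compound 2 to compound 3 (0.39 log units; beyond the scatter) both show lower numbers on arriving at tert-butyl, a modest to large rise in the number is expected on leaving it, a 3.1-fold higher number from compound 3 to compound 4 (0.49 log units; beyond the scatter). Compound 4 is therefore estimated at 60000 nM, with a range from 20000 nM to 150000 nM.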

Compound 4, concentration for 50% growth inhibition: > 100000 nM
Compound 4 gave a limit, no number; the forecaster's own chance of this, stated with the estimate: 30%; at least 1.6-fold (0.22 log units) between middle value and limit.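

The earlier compounds shown here showed only alkyl groups at this place, each with a lower number than compound 1. Methoxy gives an at least 5.1-fold higher number from compound 3 to compound 4 (0.71 log units; beyond the scatter) and an at least 2.1-fold higher number from compound 2 to compound 4 (0.32 log units; beyond the scatter), so in this assay not every group here brings the reading into the measured range. Compound 4 joins compound 1 at a limit, and the step between them cannot be read: the limit of > 100000 nM in this assay, at which 2 of the 4 values shown sit.

The compounds shown leave open whether an amine, a carboxylic acid or a longer chain at this place would give a lower number than tert-butyl. They also leave open whether ethoxy would behave like methoxy.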